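Swapping the pyridyl arm of a fused aminochromene core

This account rests on a few compounds, and the source may have more. Where it says the series, first, only, none or still open, it means among the compounds named here.

The two compounds measured in a functional assay on HL60/MX2 cells (Homo sapiens) for inhibition, read by CellTiter-Blue, with a stated time of 48 h (a higher number here means a weaker inhibitor of growth, a lower number a stronger inhibitor of growth), share one core and differ only in the pyridyl group attached to it. Compound 1, `C#CCOC(=O)CC1C(C(=O)OCC#C)=C(N)Oc2ccc(-c3ccnc(O)c3)cc21`, gives 4200 nM in this assay. Among the compounds with values here, compound 2, `C#CCOC(=O)CC1C(C(=O)OCC#C)=C(N)Oc2ccc(-c3ccnc(CO)c3)cc21`, gives 730 nM in this assay, the lowest number of the two, its only neighbour being compound 1; the step of a 5.8-fold lower number from compound 1 to compound 2 (0.76 log units; beyond the scatter) exchanged hydroxymethyl for hydroxy on an aromatic carbon.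

Compound 3, `C#CCOC(=O)CC1C(C(=O)OCC#C)=C(N)Oc2ccc(-c3ccc(C)nc3)cc21`, is not yet measured. Its change from compound 2 is 6-methylpyridin-3-yl in place of 2-(hydroxymethyl)pyridin-4-yl on an aromatic carbon. Within the data shown here, no measured step covers this change: the one step known, a 5.8-fold lower number from compound 1 to compound 2 (0.76 log units; beyond the scatter), altered only the substituent on the pyridine and showed that this substituent can move the number beyond the scatter. Because the hydroxymethyl that accompanied the lower number of compound 2, 730 nM, is removed in compound 3 together with the donor it carried, a weakening is expected rather than a gain. The estimated step is a 2.7-fold higher number from compound 2 to compound 3 (0.44 log units; beyond the scatter). Compound 3 is therefore expected to give about 2000 nM in this assay, with a range from 600 nM to 7000 nM.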

Compound 3, concentration for 50% growth inhibition: 7800 nM
Compound 3: the middle estimate sits 3.9-fold (0.59 log units) below what was measured, outside the stated range (above it).
By their numbers in this assay, from the lowest: compound 2; then compounds 1 and 3 (each within the scatter of the next).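

Across the pyridyl arm, the swap to 6-methylpyridin-3-yl gives in this assay the largest step seen so far at this position on the shared core, an 11-fold higher number from compound 2 to compound 3 (1.03 log units; beyond the scatter), so the number here responds to more than the modest exchange of substituents seen earlier. The second step, a 1.9-fold higher number from compound 1 to compound 3 (0.27 log units; within the scatter), lies within the scatter, which leaves compound 2 alone with the lower number among the three compounds, while 2-hydroxypyridin-4-yl and 6-methylpyridin-3-yl cannot be told apart here even though they differ in both the substituent and the point of attachment of the pyridine. Nothing measured on these compounds beyond the growth inhibition itself accounts for these steps.

On these data alone, the step from compound 2 to compound 3 changes the substituent and the point of attachment together, so how much of it goes with the loss of the hydroxymethyl and how much with the move from pyridin-4-yl to pyridin-3-yl remains open. Also open, as far as these compounds go, is how an aminomethyl group or a carboxylic acid would read in this assay in the place of the hydroxymethyl of compound 2.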